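Amide chain change at compound 3

The source may hold more compounds than are shown below. What is called first, only, known or untested is meant among the compounds shown, and "the series" means these compounds.

Measured in a functional assay on MCF7 cells (Homo sapiens) for antiproliferative activity, read by sulforhodamine B assay, with a stated time of 48 h; a lower number here means a stronger inhibitor, a higher number a weaker inhibitor:
- Compound 1 `COc1ccc(-c2oc3c(OC)c(OC)cc(OCCCC(=O)NCc4ccccn4)c3c(=O)c2O)cc1`: > 40000 nM (a limit)
- Compound 2 `COc1ccc(-c2oc3c(OC)c(OC)cc(OCCCCC(=O)N4CCN(C)CC4)c3c(=O)c2O)cc1`: > 40000 nM (a limit)

Compound 2 has no numerical reading, and its only result is the limit > 40000 nM. No measured value in the series is yet a number, as shown by the limit of > 40000 nM in this assay, at which 2 of the 2 values shown sit. The next compound is compound 3 `CCCCCN(C)C(=O)CCCCCOc1cc(OC)c(OC)c2oc(-c3ccc(OC)cc3)c(O)c(=O)c12`, and the change is (methyl(pentyl)carbamoyl)methyl in place of (4-methylpiperazin-1-yl)carbonyl on a saturated chain carbon, four bonds along the chain from an oxygen on an aromatic ring. In words, (methyl(pentyl)carbamoyl)methyl stands in place of (4-methylpiperazin-1-yl)carbonyl on a saturated chain carbon, four bonds along the chain from an oxygen on an aromatic ring.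

Among the measured compounds shown here, the one measured step that bears on this change is a step that the two limits leave unreadable from compound 1 to compound 2. It gives neither a size nor a direction to carry over, so no firm shift is expected in this assay. The expected step is an at least 1.1-fold lower number from compound 2 to compound 3 (0.05 log units; that floor lies within the scatter), and this estimate leans on no measured trend. For compound 3 the estimated value is 35000 nM, with an expected range of 12000 nM to 60000 nM.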

Compound 3, half-maximal inhibitory concentration: 34900 nM
The estimate for compound 3 lay 1.0-fold (0.00 log units) above the measured number; measured number inside the range.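

In this assay, among the compounds shown here, compound 3 gives 34900 nM as the first number rather than a limit, with (methyl(pentyl)carbamoyl)methyl, which has no ring, at this position. The steps read an at least 1.1-fold lower number from compound 2 to compound 3 (0.05 log units; that floor lies within the scatter) and an at least 1.1-fold lower number from compound 1 to compound 3 (0.05 log units; that floor lies within the scatter) and each is only a floor, so this change gives a numerical reading but no established gain in potency. The step between compound 1 and compound 2 still cannot be read, and both compounds remain limits: the limit of > 40000 nM in this assay, at which 2 of the 3 values shown sit.

As far as these compounds go, whether a carboxylic acid or a primary amine at the end of this chain would move the number beyond the scatter stays open. From the compounds shown here alone, with only compound 3 giving a number, the effect of a longer chain or of a shorter alkyl group on the amide nitrogen also stays open.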